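Three inactive ureas and a chloro analogue still to be tested

A few compounds are considered here, and "the series" means these few. Any claim that something is new, unique, unknown or untested is made for them only; others in the source may bear on it.

The study concerns acylurea-type compounds built on a shared core and examined in a functional assay on the whole organism with Rattus norvegicus as the target, with a stated time of 5 days; on this read-out lower numbers stand for an effect already at smaller amounts and higher numbers for an effect only at larger amounts of compound. Compound 1 `Cc1cccc(Cl)c1NC(=O)/N=C1\CCCN1C` carries a methyl and a chloro on its aromatic ring. In this assay compound 1 gives > 25 mg/kg, which is a limit of the assay rather than a number. Compound 2 `CCc1cccc(CC)c1NC(=O)/N=C1\CCCN1C` carries two ethyl groups instead. In this assay compound 2 gives > 25 mg/kg, again a limit. Compound 3 `CN1CCC/C1=N\C(=O)Nc1cccc(C(F)(F)F)c1` carries a trifluoromethyl on the aromatic ring. In this assay compound 3 gives > 25 mg/kg, likewise only a limit. Compound 3 thus stands where all three measured compounds stand, at the limit of > 25 mg/kg in this assay, at which 3 of the 3 values shown sit; no steps between them can be measured, and nothing separates compound 3 from compound 1 or compound 2 on the numbers shown.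

Compound 4 `CN1CCC/C1=N\C(=O)Nc1cccc(Cl)c1` differs from compound 3 in one place: chloro in place of trifluoromethyl on an aromatic carbon. Since the measured compounds all sit at a limit, the step from compound 3 to compound 4 in this assay is expected to be none beyond the scatter, a number no higher from compound 3 to compound 4 (the limit leaves the size open). Compound 4 is therefore expected to give about 25 mg/kg in this assay, within a range from 12 mg/kg to 60 mg/kg, most likely reported as a limit once more.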

Compound 4, minimum effective dose: 15 mg/kg
Compound 4: the middle estimate sits 1.7-fold (0.22 log units) above what was measured, and the stated range covers the measured number.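

In this assay, among the compounds shown here, compound 4 gives 15 mg/kg, the first actual number in this set, which shows that a change of group on this aromatic carbon can bring a measurable dose into view. Chloro in place of trifluoromethyl there gives an at least 1.6-fold lower number from compound 3 to compound 4 (0.22 log units; that floor lies within the scatter); one end of this step is a limit, so its true size stays open, and the smallest size it can have does not by itself pass the scatter. Compound 4 is also alone in this set in giving a number, with the other compounds still held at the same limit: the limit of > 25 mg/kg in this assay, at which 3 of the 4 values shown sit.

The compounds shown leave open whether another group on this aromatic carbon, such as bromo, methoxy or a nitrile, would give a number in this assay, and whether that number would lie beyond the scatter from the one for compound 4. They also leave open how a longer chain in place of the methyl on the shared core would read alongside chloro on the aromatic ring.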